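Heteroaryl ether returns in place of a sulfanyl group

This account rests on a few compounds, and the source may have more. Where it says the series, first, only, none or still open, it means among the compounds named here.

Measured so far in a functional assay on Jurkat cells (Homo sapiens) for inhibition (on this read-out lower numbers stand for stronger inhibition and higher numbers for weaker inhibition), all on the shared core of compound 1:
compound 1, `COC(=O)c1cc(OCC(=O)[C@H](CC(=O)O)NC(=O)[C@@H](NC(=O)COc2cccc3ccccc23)C(C)C)no1`: 71000 nM
compound 2, `CC(C)[C@H](NC(=O)COc1cccc2ccccc12)C(=O)N[C@@H](CC(=O)O)C(=O)CSc1nncn1C`: > 200000 nM
compound 3, `CC(C)[C@H](NC(=O)COc1cccc2ccccc12)C(=O)N[C@@H](CC(=O)O)C(=O)CSc1nnnn1-c1ccccc1`: 153000 nM.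

Compound 2 has only a limit of the assay, (the limit of > 200000 nM in this assay, at which 1 of the 3 values shown sits), not a number. The step of an at least 2.8-fold higher number from compound 1 to compound 2 (0.44 log units; beyond the scatter) and the step of a 2.2-fold higher number from compound 1 to compound 3 (0.33 log units; beyond the scatter) both run the same way: each time a heteroaryl group joined through oxygen gave way to one joined through sulfur, the number rose beyond the scatter. Between the two sulfanyl analogues the difference is an at least 1.3-fold lower number from compound 2 to compound 3 (0.11 log units; that floor lies within the scatter), which says nothing about order.

Compound 4, `CC(C)[C@H](NC(=O)COc1cccc2ccccc12)C(=O)N[C@@H](CC(=O)O)C(=O)COc1cc(C(F)(F)F)ncn1`, awaits measurement. It differs from compound 2 by (6-(trifluoromethyl)pyrimidin-4-yl)oxy in place of (4-methyl-4H-1,2,4-triazol-3-yl)sulfanyl on a saturated chain carbon bound to a carbonyl carbon. The change runs in the direction opposite to the two steps from compound 1, since a heteroaryl group joined through oxygen comes back, though the ring itself is not one seen in the series. On that basis a lower number than for compound 2 is expected for compound 4, roughly the step from compound 1 to compound 2 run in reverse. Compound 4 is thus expected to show an at least 2.5-fold lower number from compound 2 to compound 4 (0.39 log units; beyond the scatter). The estimate for compound 4 is 80000 nM, within 30000 nM to 250000 nM.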

Compound 4, half-maximal inhibitory concentration: > 200000 nM
Compound 4: no number, only a limit (the forecaster's own chance of this, stated with the estimate: 25%); at least 2.5-fold (0.39 log units) between middle value and limit.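

The oxygen link alone does not carry the lower number at this position: with 6-(trifluoromethyl)pyrimidin-4-yl in place of 5-(methoxycarbonyl)-1,2-oxazol-3-yl on the same oxygen, the result is an at least 2.8-fold higher number from compound 1 to compound 4 (0.44 log units; beyond the scatter), so compound 4 goes against the earlier pairing of oxygen-linked groups with lower numbers, and compound 1 remains the strongest inhibitor of the four, with steps to all the others printed as beyond the scatter. Against the phenyl-tetrazole sulfanyl analogue, the result is an at least 1.3-fold higher number from compound 3 to compound 4 (0.11 log units; that floor lies within the scatter), which gives no order. In this assay, compound 4 has only a limit and not a number, as does compound 2, so the step joining them cannot be read: the limit of > 200000 nM in this assay, at which 2 of the 4 values shown sit.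

The compounds shown do not separate the effect of the linking atom from that of the ring, as 5-(methoxycarbonyl)-1,2-oxazol-3-yl joined through sulfur or 4-methyl-4H-1,2,4-triazol-3-yl joined through oxygen would. On these data alone, whether a methoxycarbonyl group or an amine in place of the trifluoromethyl on the pyrimidine would lower the number also stays open.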